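A few compounds are considered here, and "the series" means these few. Any claim that something is new, unique, unknown or untested is made for them only; others in the source may bear on it.

Measured compounds:
- compound 1 `O=C(COc1ccc(C(=O)/C=C/c2cccc(Cl)c2)cc1)N[C@H]1CCOC1=O`: 4990 nM
- compound 2 `O=C1OCC[C@@H]1NC(=S)SCCOc1cccc2ccccc12`: > 64000 nM
- compound 3 `O=C1OCC[C@@H]1NC(=S)SCCOc1ccccc1`: > 64000 nM

Of the compounds shown here, three have been tested in a functional assay on PC-3 cells (Homo sapiens) for antiproliferative activity, read by MTT assay, with a stated time of 72 h; on this read-out higher numbers stand for weaker inhibition and lower numbers for stronger inhibition. Compound 1 is the only one of the three that gives a number, with 4990 nM. Compound 2 gives only a limit, > 64000 nM. Compound 3 likewise gives only a limit, > 64000 nM. For the measured compounds named here, the two limits share the same boundary, (the limit of > 64000 nM in this assay, at which 2 of the 3 values shown sit), so nothing can be said about how compound 2 and compound 3 compare with each other, and no step between measured compounds is available.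

Compound 4 `CC(C)c1ccc(/C=C/C(=O)c2ccc(OCC(=O)N[C@H]3CCOC3=O)cc2)cc1` has not yet been measured. It differs from compound 1 in one place: 4-isopropylphenyl in place of 3-chlorophenyl on a double-bonded chain carbon bound to a double-bonded chain carbon. The rest of the molecule, the chain with its carbonyl and the ring-opened amide link to the five-membered lactone, is kept unchanged.

Going by the values given here, with no measured step to lean on, the expectation for compound 4 rests on compound 1 alone. The swap of one aromatic substituent for another on the same chain carbon is expected to move the read-out of this assay by at most a small amount, and the estimated step of a 1.2-fold higher number from compound 1 to compound 4 (0.08 log units; within the scatter) is taken to lie within the usual scatter. Compound 4 is therefore expected to give about 6000 nM in this assay, most plausibly between 1500 nM and 25000 nM.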

Compound 4, half-maximal inhibitory concentration: 4660 nM
Estimate against measurement, compound 4: 1.3-fold (0.11 log units) above, within the range that was stated.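

For the compounds shown here, the first step that can be read in this assay is a 1.1-fold lower number from compound 1 to compound 4 (0.03 log units; within the scatter), so this is the first direct look at what a change on the double-bonded chain carbon bound to a double-bonded chain carbon does to the read-out. The swap replaces the chlorine of 3-chlorophenyl with the all-carbon isopropyl group and also changes where the substituent sits on the ring, yet the two values remain within the usual scatter, so in this pair the chlorine is not needed to keep the read-out at this level. Nothing shown gives a reason why this change leaves the read-out in place.

Compound 2 and compound 3 each give only a limit, so no step involving either can be read: the limit of > 64000 nM in this assay, at which 2 of the 4 values shown sit.
Going by these compounds, it remains open whether this position would tolerate a group of a different kind, such as an aromatic ring carrying an amine or a carboxylic acid, or a longer chain, and whether separating the two parts of this swap, with 4-chlorophenyl for example, would reveal any effect.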